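Trimming the Ring Substituent of Compound 2

A few compounds are considered here, and "the series" means these few. Any claim that something is new, unique, unknown or untested is made for them only; others in the source may bear on it.

Among the two compounds measured in a functional assay on A549 cells (Homo sapiens) for antiproliferative activity, read by MTT assay, with a stated time of 72 h (on this read-out higher numbers stand for weaker inhibition and lower numbers for stronger inhibition), compound 2 `c1cnc2ccc(Nc3ncnc4ccc(-c5cnn(C6CCNCC6)c5)cc34)cc2c1` stands at the top of the numbers: in this assay compound 2 gives 32000 nM. For the measured compounds named here, its only neighbour, compound 1 `CC(Nc1ncnc2ccc(-c3cnn(C4CCNCC4)c3)cc12)c1c(Cl)ccc(F)c1Cl`, gives 7000 nM in this assay, and the single measured step, a 4.6-fold higher number from compound 1 to compound 2 (0.66 log units; beyond the scatter), concerns the group on the nitrogen attached to the shared core.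

Compound 3 `Cn1cc(-c2ccc3ncnc(Nc4ccc5ncccc5c4)c3c2)cn1` is the next analogue, and it differs from compound 2 at another place: methyl in place of piperidin-4-yl on an aromatic nitrogen. Going by the values given here, no measured step touches this position, so the step from compound 1 to compound 2 bears on it only in showing how far the numbers of this series have moved so far, and nothing in the data points to a direction for the present change. On this basis no step beyond the scatter is expected in this assay, and the expected step is no change at the digits printed from compound 2 to compound 3 (within the scatter). For compound 3 the estimate in this assay is therefore 32000 nM, with a range from 10000 nM to 100000 nM.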

Compound 3, half-maximal inhibitory concentration: 1380 nM
Beside the measured number, compound 3's estimate is 23-fold (1.37 log units) above it, and the stated range ends above it.
By their numbers in this assay, from the lowest: compound 3; then compound 1; then compound 2.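

For the compounds shown here, replacing piperidin-4-yl with methyl on the aromatic nitrogen gives a 23-fold lower number from compound 2 to compound 3 (1.37 log units; beyond the scatter) in this assay, showing that this position, which no earlier step touched, can move the numbers strongly. This step is large, whereas the earlier change at the group on the nitrogen attached to the shared core, a 4.6-fold higher number from compound 1 to compound 2 (0.66 log units; beyond the scatter), was modest. The change removes a six-membered non-aromatic ring with its hydrogen-bond donor and acceptor and leaves a single carbon, but the data offer no measured explanation for the lower number, and nothing separates the loss of the ring from the loss of its nitrogen.

Only the two ends of this comparison are shown, so it remains open whether an ethyl group, a longer chain ending in an amine or a cyclohexyl ring would fall nearer to compound 3 or to compound 2 in this assay. As far as these compounds go, it also remains open whether methyl in place of piperidin-4-yl would give a step of similar size with the 1-(2,6-dichloro-3-fluorophenyl)ethyl group of compound 1 in place of quinolin-6-yl.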